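The compounds below may be only part of what the source reports. "The series", "measured", "known", "first", "only" and "open" are said of these compounds alone.

Measured so far in an assay on microsomes from liver for inhibition of 3-hydroxy-3-methylglutaryl-coenzyme A reductase (Rattus norvegicus); a higher number here means a weaker inhibitor, a lower number a stronger inhibitor:
- compound 1, `CC(C)c1c(C(=O)N2CCCCC2)nn(-c2ccc(F)cc2)c1OC[C@@H](O)C[C@@H](O)CC(=O)O`: 47 nM
- compound 2, `CC(C)c1c(C(=O)N(C)Cc2cccc(Cl)c2)nn(-c2ccc(F)cc2)c1OC[C@@H](O)C[C@@H](O)CC(=O)O`: 8.3 nM

Compound 2 holds the lower of the two numbers in this assay. Going by the values given here, the only step between measured compounds, a 5.7-fold lower number from compound 1 to compound 2 (0.75 log units; beyond the scatter), sets compound 2 clearly apart from compound 1.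

Compound 3 is `CC(C)c1c(C(=O)N(C)Cc2ccc(F)cc2)nn(-c2ccc(F)cc2)c1OC[C@@H](O)C[C@@H](O)CC(=O)O`, not yet tested in this assay. Its change from compound 2 reads: 4-fluorophenyl in place of 3-chlorophenyl on a saturated chain carbon bound to an amide-type nitrogen. Among the compounds with values here, no measured pair varies the halogen or its position on this benzyl ring, so nothing directly bears on the change. Within the data shown here, the step from compound 1 to compound 2 touches the same region of the molecule but exchanges the whole amine part of the carbonyl, not one aryl substituent for another; it shows only that this region admits change, and its size is no guide to the present one. With nothing comparable in hand, the step in this assay from compound 2 to compound 3 is expected to be small, at most a modest weakening, and may well stay within the scatter.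

The step expected from compound 2 to compound 3 is a 1.4-fold higher number from compound 2 to compound 3 (0.16 log units; within the scatter). For compound 3 the estimated number is 12 nM, with a range from 4 nM to 35 nM.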

Compound 3, half-maximal inhibitory concentration: 18 nM
Estimate against measurement, compound 3: 1.5-fold (0.18 log units) below, within the range that was stated.
By their numbers in this assay, from the lowest: compound 2; then compound 3; then compound 1.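

In this assay, the aryl group on the saturated chain carbon bound to an amide-type nitrogen proves to be a position that responds to a single exchange: 4-fluorophenyl in place of 3-chlorophenyl gives a step beyond the scatter (a 2.2-fold higher number from compound 2 to compound 3 (0.34 log units; beyond the scatter)), although both groups count the same heavy atoms and the same ring. The gain over the piperidin-1-yl amide is not confined to the 3-chlorobenzyl compound, as the (4-fluorobenzyl)(methyl)amino group also gives a lower number (a 2.6-fold lower number from compound 1 to compound 3 (0.42 log units; beyond the scatter)), so both benzyl amides shown stand below compound 1. No measurement here accounts for the difference between the two halogenated benzyl groups.

The exchange changes the halogen and its ring position together, so the two remain unseparated; a 4-chlorophenyl or 3-fluorophenyl group at this place would divide them. Also open, going by these compounds, are the unsubstituted phenyl group at this place and the effect of the methyl on the amide nitrogen, which a secondary amide carrying the amide hydrogen in its place would address.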